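The source may hold more compounds than are shown below. What is called first, only, known or untested is meant among the compounds shown, and "the series" means these compounds.

In a functional assay on L1210 cells (Mus musculus), with a stated time of 48 h; on this read-out lower numbers stand for stronger inhibition and higher numbers for weaker inhibition:
- compound 1 `CCCCC(=O)C(C)Nc1cc(NC(=O)OCC)nc(N)c1[N+](=O)[O-]`: 54000 nM
- compound 2 `CCOC(=O)Nc1cc(NC(C)C(O)COc2ccccc2)c([N+](=O)[O-])c(N)n1`: 55000 nM
- compound 3 `CCOC(=O)Nc1cc(NC(C)C(O)Cc2ccccc2)c([N+](=O)[O-])c(N)n1`: 53000 nM

Compound 3 stands level with the other two, and its steps to both lie within the scatter. Compound 4 `CCCCC(O)C(C)Nc1cc(NC(=O)OCC)nc(N)c1[N+](=O)[O-]` carries propyl in place of phenyl on a saturated chain carbon, two bonds along the chain from an oxygen on a saturated carbon. For the measured compounds named here, two measured steps bear on this change. Phenyl in place of phenoxy at that same place gave a 1.0-fold lower number from compound 2 to compound 3 (0.02 log units; within the scatter). Replacing butylcarbonyl with 1-hydroxy-2-phenylethyl gave a 1.0-fold lower number from compound 1 to compound 3 (0.01 log units; within the scatter). Both are within the scatter, so no step beyond the scatter is expected in this assay, in either direction. The expected change is a 1.0-fold lower number from compound 3 to compound 4 (0.01 log units; within the scatter). For compound 4 the estimated value is 52000 nM, with an expected range of 28000 nM to 95000 nM.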

Compound 4, half-maximal inhibitory concentration: 55000 nM
Compound 4: middle estimate off by 1.1-fold (0.02 log units), on the low side, within the range that was stated.
By their numbers in this assay, from the lowest: compounds 3, 1, 2 and 4 (each within the scatter of the next).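

In this assay the step of a 1.0-fold higher number from compound 3 to compound 4 (0.02 log units; within the scatter) comes with propyl in place of phenyl, so at this place, on a saturated chain carbon two bonds along the chain from an oxygen on a saturated carbon, an aromatic ring is not needed to hold the number. The step of no change at the digits printed from compound 2 to compound 4 (within the scatter) with propyl in place of phenoxy and the step of a 1.0-fold higher number from compound 1 to compound 4 (0.01 log units; within the scatter) with 1-hydroxypentyl in place of butylcarbonyl agree: all four compounds stand level. Still open, going by these compounds, is whether an amine, a carboxylic acid or a much longer chain here would move the number beyond the scatter. Nothing shown here bears on why the number stays level.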